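The compounds below may be only part of what the source reports. "The series", "measured", "known", "first", "only" and "open" are said of these compounds alone.

Compound 1 `COc1ccc(CNCCCNS(=O)(=O)c2cc(C(F)(F)F)cc(C(F)(F)F)c2)cc1` and compound 2 `COc1cccc(CNCCCNS(=O)(=O)c2cc(C(F)(F)F)cc(C(F)(F)F)c2)c1` differ only in where the methoxy group sits on the aromatic ring that hangs from the amine nitrogen. In a toxicity assay on MCF-10A cells (Homo sapiens) for inhibition, read by MTT assay, with a stated time of 72 h (on this read-out higher numbers stand for weaker inhibition of growth and lower numbers for stronger inhibition of growth), compound 1 gives 3100 nM, and in this assay compound 2 gives 6600 nM. Going by the values given here, the single step between them, a 2.1-fold higher number from compound 1 to compound 2 (0.33 log units; beyond the scatter), shows that moving the methoxy group from one ring position to another changed the number by a modest but real amount. Among the two measured compounds, compound 2 carries the higher number, with compound 1 as its only neighbour.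

Compound 3 `COc1ccccc1CNCCCNS(=O)(=O)c1cc(C(F)(F)F)cc(C(F)(F)F)c1` is the next member of the series. Its change from compound 2 is 2-methoxyphenyl in place of 3-methoxyphenyl on a saturated chain carbon bound to an amine nitrogen, so the methoxy group is again shifted on the same ring. Among the compounds with values here, the only measured step that bears on this is the one from compound 1 to compound 2, which was modest, so a step of similar or smaller size is expected, in either direction, quite possibly within the scatter. For compound 3 in this assay the estimate is 6000 nM, with a range from 2500 nM to 15000 nM. The expected step from compound 2 to compound 3 is therefore a 1.1-fold lower number from compound 2 to compound 3 (0.04 log units; within the scatter).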

Compound 3, concentration for 50% growth inhibition: 5500 nM
The estimate for compound 3 lay 1.1-fold (0.04 log units) above the measured number; the measured number falls inside the stated range.
By their numbers in this assay, from the lowest: compounds 1, 3 and 2 (each within the scatter of the next, the first and the last beyond it).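

Swapping 3-methoxyphenyl for 2-methoxyphenyl gives a 1.2-fold lower number from compound 2 to compound 3 (0.08 log units; within the scatter), and swapping 4-methoxyphenyl for 2-methoxyphenyl gives a 1.8-fold higher number from compound 1 to compound 3 (0.25 log units; within the scatter), so in this assay the 2-methoxyphenyl compound cannot be told apart from either of the other two. The earlier pair suggested that the place of the methoxy group on this ring might matter, but the new compound adds no further separation: among these three compounds, only the gap between the 4-methoxyphenyl and 3-methoxyphenyl groups lies beyond the scatter, and that step is modest. Nothing available explains why these three numbers fall where they do.

These three compounds differ only in the place of one methoxy group, so they cannot show whether a different group on the ring, such as a chlorine atom or a hydroxy group, or a plain benzyl group with no methoxy at all, would shift the number further. From the compounds shown here alone, a longer chain between the two nitrogens, or a replacement for the two trifluoromethyl groups, also remains open, as does whether the small effect of moving the methoxy group would hold on such altered compounds.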